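Shifting the carboxyphenoxy linker on the shared core

The compounds below may be only part of what the source reports. "The series", "measured", "known", "first", "only" and "open" are said of these compounds alone.

Three compounds on the shared core of compound 1 `CN(Cc1ccc(C(=O)O)cc1)c1ccc(OCc2c(-c3c(Cl)cccc3Cl)noc2C2CC2)nc1C(F)(F)F` were tested in a functional assay on HEK293 cells for agonist activity at Bile acid receptor (Homo sapiens), read by a luciferase reporter; on this read-out higher numbers stand for an effect only at larger amounts of compound and lower numbers for an effect already at smaller amounts; compound 1 gives 6 nM. Compound 2 `CC(c1ccc(OCc2c(-c3c(Cl)cccc3Cl)noc2C2CC2)nc1C(F)(F)F)N(C)c1ccc(C(=O)O)cc1` gives 182 nM in this assay, and compound 3 `O=C(O)c1ccccc1OCc1ccc(OCc2c(-c3c(Cl)cccc3Cl)noc2C2CC2)nc1C(F)(F)F` gives 611 nM, the highest of the three numbers, beyond the scatter from both neighbours. Among the measured compounds shown here, the one step measured into compound 3 is large: a 100-fold higher number from compound 1 to compound 3 (2.01 log units; beyond the scatter). Compound 4 `CC(Oc1cccc(C(=O)O)c1)c1ccc(OCc2c(-c3c(Cl)cccc3Cl)noc2C2CC2)nc1C(F)(F)F` differs from compound 3 by 1-(3-carboxyphenoxy)ethyl in place of (2-carboxyphenoxy)methyl on an aromatic carbon. For the measured compounds named here, no measured step covers this exact change. Compound 1 gives 6 nM and compound 2, which differs from it only by a methyl on the linker carbon, gives 182 nM, but there the carboxylate position is unchanged, and that pair is not a step shown for the carboxyphenoxy series. For compound 4 the expected step of a 1.5-fold higher number from compound 3 to compound 4 (0.17 log units; within the scatter) is therefore small and uncertain, if anything toward a higher number. Compound 4 is estimated at 900 nM in this assay, within a range from 150 nM to 5000 nM.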

Compound 4, half-maximal effective concentration: 58 nM
Compound 4: the middle estimate sits 16-fold (1.19 log units) above what was measured, and the stated range ends above it.
By their numbers in this assay, from the lowest: compound 1; then compound 4; then compound 2; then compound 3.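

In this assay, 1-(3-carboxyphenoxy)ethyl in place of (2-carboxyphenoxy)methyl gives an 11-fold lower number from compound 3 to compound 4 (1.02 log units; beyond the scatter), so at this aromatic carbon an oxygen-linked carboxyphenyl group is not tied to the high number of compound 3. Replacing the (4-carboxyphenyl)(methyl)amino group on the same saturated chain carbon with 3-carboxyphenoxy gives a 3.1-fold lower number from compound 2 to compound 4 (0.50 log units; beyond the scatter), yet a 9.7-fold higher number from compound 1 to compound 4 (0.99 log units; beyond the scatter) still remains, leaving compound 1 with the lowest number of the four. Nothing available explains these steps.

The step from compound 3 moves the carboxylic acid on the ring and adds a methyl on the linker carbon together, so the compounds shown cannot say how much each change contributes. A (3-carboxyphenoxy)methyl group and a 1-(2-carboxyphenoxy)ethyl group would separate the two.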